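Swapping one end group of compound 2

A few compounds are considered here, and "the series" means these few. Any claim that something is new, unique, unknown or untested is made for them only; others in the source may bear on it.

Of the compounds shown here, three with a shared core have been measured so far in a functional assay on PC-3 cells (Homo sapiens) for antiproliferative activity, read by MTT assay, with a stated time of 48 h (on this read-out lower numbers stand for stronger inhibition and higher numbers for weaker inhibition), on this series. Compound 1 (`COc1ccc(CN(C(=O)CSc2nc3ccccc3s2)c2cc(OC)c(OC)c(OC)c2)cc1[N+](=O)[O-]`) gives 26500 nM as its result. Compound 2 (`COc1ccc2nc(SCC(=O)N(Cc3ccc(OC)c(O)c3)c3cc(OC)c(OC)c(OC)c3)sc2c1`) gives 4110 nM as the lowest number of the set, lower than the number of compound 1. Compound 3 (`COc1ccc(CN(C(=O)CSc2nc3ccccc3s2)c2cc(OC)c(OC)c(OC)c2)cc1OC`) gives > 80000 nM as a limit of the assay and not a number. Compound 4 (`COc1ccc(CN(C(=O)CSc2nc3cc(Br)ccc3s2)c2cc(OC)c(OC)c(OC)c2)cc1O`) is not yet measured and differs from compound 2 by a single swap (a group of 10 heavy atoms (7 carbon, 1 nitrogen, 1 sulfur, 1 bromine; one five-membered aromatic ring with 2 hetero atoms, one six-membered aromatic ring of carbon only) in place of a group of 11 heavy atoms (8 carbon, 1 nitrogen, 1 oxygen, 1 sulfur; one five-membered aromatic ring with 2 hetero atoms, one six-membered aromatic ring of carbon only), on a sulfur) and nothing more. Among the compounds with values here, the only measured step (an at least 3.0-fold higher number from compound 1 to compound 3 (0.47 log units; beyond the scatter)) is methoxy in place of nitro, beyond the scatter, at another place than the one changing now. It shows that one swap can matter in this assay but gives no direction for this new swap. No clear shift is therefore expected, and the estimated step (a 1.2-fold higher number from compound 2 to compound 4 (0.09 log units; within the scatter)) carries a wide margin. Compound 4 is estimated at 5000 nM with an expected range (1500 nM to 18000 nM) around it.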

Compound 4, half-maximal inhibitory concentration: 8210 nM
Estimate against measurement, compound 4: 1.6-fold (0.22 log units) below, and the stated range covers the measured number.
By their numbers in this assay, from the lowest: compounds 2 and 4 (each within the scatter of the next); then compound 1. At a limit, above all of these: compound 3.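

In this assay, the group on the sulfur changes from 6-methoxy-1,3-benzothiazol-2-yl to a group of the same ring types that carries bromine and has no oxygen, and this gives a 2.0-fold higher number from compound 2 to compound 4 (0.30 log units; within the scatter). This is the first step shown at this place, and the earlier methoxy-for-nitro step, made elsewhere on the molecule, could say nothing about it. Here, the exchange of this end group does not separate the two compounds, so this place accepts both groups in this assay. No measurement shown explains this outcome.

With only these two groups shown on the sulfur, one step says little about this place as a whole. As far as these compounds go, whether an amine or a carboxylic acid on that end group would move the number beyond the scatter remains open.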